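From Methoxycarbonyl Back to an Aryl Group

The source may report more compounds than this note shows. Statements on the series, on what has been measured and on what is new or still open speak of the compounds shown alone.

Compound 3 `COC(=O)Cn1cc(CNC(=O)c2cnc(Nc3ccc(C#N)cc3)cc2Oc2c(C)cc(C)cc2C)nn1` holds the lowest of the two numbers in an ADME assay on MT4 cells (Homo sapiens) for cytotoxicity, read by MTT assay, with a stated time of 5 days; on this read-out higher numbers stand for lower toxicity in this test and lower numbers for higher toxicity in this test; in this assay compound 3 gives 13800 nM. Its nearest neighbour is compound 1 `Cc1ccc(Cn2cc(CNC(=O)c3cnc(Nc4ccc(C#N)cc4)cc3Oc3c(C)cc(C)cc3C)nn2)cc1`, which in this assay gives 165000 nM. Compound 2 `Cc1cc(C)c(Oc2cc(Nc3ccc(C#N)cc3)ncc2C(=O)NCc2cn(Cc3ccccc3F)nn2)c(C)c1` reaches only a limit of this assay, > 222000 nM (the limit of > 222000 nM in this assay, at which 1 of the 3 values shown sits). Compound 4 `Cc1cc(C)c(Oc2cc(Nc3ccc(C#N)cc3)ncc2C(=O)NCc2cn(Cc3ccc([N+](=O)[O-])cc3)nn2)c(C)c1` differs from compound 3 by 4-nitrophenyl in place of methoxycarbonyl on a saturated chain carbon bound to an aromatic nitrogen. Within the data shown here, two measured steps bear on this change: a 12-fold lower number from compound 1 to compound 3 (1.08 log units; beyond the scatter) and an at least 16-fold lower number from compound 2 to compound 3 (1.20 log units; beyond the scatter), both exchanging an aryl group for methoxycarbonyl and both large. The change to compound 4 runs the other way, so a large rise in this assay is expected. The expected step is an 11-fold higher number from compound 3 to compound 4 (1.04 log units; beyond the scatter). Compound 4 is therefore estimated to give about 150000 nM, within 50000 nM and 300000 nM.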

Compound 4, half-maximal cytotoxic concentration: >= 139000 nM
Compound 4 ended at the assay's limit; the forecaster's own chance of this, stated with the estimate: 35%; the middle value is on the limit's open side.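

In this assay, the change to 4-nitrophenyl gives an at least 10-fold higher number from compound 3 to compound 4 (1.00 log units; beyond the scatter), so a third aryl group, this one carrying nitro, stands apart from methoxycarbonyl, as those of compound 1 and compound 2 do. The value of compound 4, >= 139000 nM, is a limit of the assay and not a number. The steps from compound 1 and compound 2 to compound 4 cannot be read, which leaves the three aryl groups unranked. Going by these compounds, it remains open whether a carboxylic acid, an amine or a longer alkyl chain in place of methoxycarbonyl would give a low number like that of compound 3.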